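The source may hold more compounds than are shown below. What is called first, only, known or untested is meant among the compounds shown, and "the series" means these compounds.

Measured so far in a physicochemical assay for solubility, using the shake flask method, in phosphate buffer, with a stated time of 20 h, at pH 6.5; on this read-out lower numbers stand for lower solubility and higher numbers for higher solubility
- compound 1 `C[S+]([O-])c1ccc(-c2cnc3ccc(-c4ccc(S(C)(=O)=O)cc4)nn23)cc1` gives 5000 nM
- compound 2 `CCN(CC)Cc1cc(-c2cnc3ccc(-c4cccc([S+](C)[O-])c4)nn23)ccc1F` gives 200000 nM
- compound 3 `C[S+]([O-])c1cccc(-c2ccc3ncc(Nc4cccc(S(C)(=O)=O)c4)n3n2)c1` gives 40000 nM

Compound 3 stands second highest of the three, under compound 2 and over compound 1, with both gaps beyond the usual scatter. Compound 4 `C[S+]([O-])c1cccc(Nc2cnc3ccc(-c4cccc([S+](C)[O-])c4)nn23)c1` differs from compound 3 on an aromatic carbon, where a group of 3 heavy atoms replaces methylsulfonyl (a group of 3 heavy atoms (1 carbon, 1 oxygen, 1 sulfur; no ring) in place of a group of 4 heavy atoms (1 carbon, 2 oxygen, 1 sulfur; no ring), on an aromatic carbon). Within the data shown here, no measured pair differs in one place, so direct precedent is lacking. Compound 1, carrying methylsulfonyl, reads 5000 nM and compound 2, carrying none, reads 200000 nM with other parts differing too. A small rise in this assay, about the size of the scatter, is expected (a 2.0-fold higher number from compound 3 to compound 4 (0.30 log units; within the scatter)). For compound 4 the estimated value is 80000 nM (range 30000 nM to 200000 nM).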

Compound 4, solubility: 150000 nM
Compound 4: the middle estimate sits 1.9-fold (0.27 log units) below what was measured; measured number inside the range.
By their numbers in this assay, from the lowest: compound 1; then compound 3; then compounds 4 and 2 (each within the scatter of the next).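

Among these compounds, this is the first one-place comparison: on this aromatic carbon, replacing methylsulfonyl with the group of 3 heavy atoms gives a 3.8-fold higher number from compound 3 to compound 4 (0.57 log units; beyond the scatter) in this assay. The read-out therefore responds to a change at this position alone, with the rest of the structure held constant. Nothing available explains the size or direction of this step.

On these data alone, it remains open how a carboxylic acid or a nitrile on this carbon would read. As far as these compounds go, whether the same replacement gives a similar step on other cores also remains open.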